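Adding a Methyl to the Aryl Amine of Compound 3

The compounds below may be only part of what the source reports. "The series", "measured", "known", "first", "only" and "open" are said of these compounds alone.

Of the compounds shown here, three sharing one core have been tested in a functional assay on the whole organism (strain Wistar) for inhibition, with Rattus norvegicus as the target, read by paw edema, with a stated time of 3 h, at a dose of 10 mg/kg by the oral route; on this read-out lower numbers stand for less inhibition and higher numbers for more inhibition at the one dose given (going by the name of the read-out). Compound 1 `CCCCNc1nnc(COc2ccc(-c3ccccc3)cc2)s1` gives 27.3%. Compound 2 `Clc1ccc(Nc2nnc(COc3ccc(-c4ccccc4)cc3)s2)cc1` gives 52.3%. Compound 3 `Cc1ccccc1Nc1nnc(COc2ccc(-c3ccccc3)cc2)s1` gives 25%, the lowest of the three numbers, although its gap to compound 1 lies within the usual scatter and only compound 2 stands clearly apart from it. The measured steps were a number 25 percentage points higher from compound 1 to compound 2 (beyond the scatter), a number 2.3 percentage points lower from compound 1 to compound 3 (within the scatter) and a number 27.3 percentage points lower from compound 2 to compound 3 (beyond the scatter).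

Compound 4 `Cc1ccc(Nc2nnc(COc3ccc(-c4ccccc4)cc3)s2)c(C)c1` differs from compound 3 by one change: methyl in place of hydrogen on an aromatic carbon. Going by the values given here, no measured step adds a methyl to this phenyl ring, so none bears on the change directly. The nearest comparison is the swap of 4-chlorophenyl for 2-methylphenyl between compound 2 and compound 3, which changed the number modestly, but that swap moved the group from one ring position to another as well as changing its identity. The expectation for compound 4 is therefore a small upward step, a number 8 percentage points higher from compound 3 to compound 4 (within the scatter), not clearly beyond the scatter. Compound 4 is estimated at 33%, within 15% to 55%.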

Compound 4, a percentage reported as inhibition, in the whole organism at one dose (the size of the read-out at that dose, not a potency): 56.8%
Estimate against measurement, compound 4: 23.8 percentage points below, outside the stated range (above it).
By their numbers in this assay, from the lowest: compounds 3 and 1 (each within the scatter of the next); then compounds 2 and 4 (each within the scatter of the next).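

In this assay, one methyl in place of hydrogen on the aromatic carbon para to the large group gives a number 31.8 percentage points higher from compound 3 to compound 4 (beyond the scatter) and so shows that this position responds strongly to a very small change. The 2,4-dimethylphenyl group of compound 4 also gives a number 4.5 percentage points higher from compound 2 to compound 4 (within the scatter) and a number 29.5 percentage points higher from compound 1 to compound 4 (beyond the scatter), so among the aryl amines shown, the two with a group at the 4 position of the phenyl ring, compound 2 and compound 4, sit together and clearly apart from compound 3. Nothing shown explains why this single methyl moves the number so far.

On these data alone, it remains open whether a 4-methylphenyl group, without the 2-methyl, would give a similar number. As far as these compounds go, it is equally open how a methoxy group, an ethyl group or an amine would behave at this same position.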